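Thiazol-2-yl in Place of Pyridin-2-yl in an H2 Agonist Series

This account rests on a few compounds, and the source may have more. Where it says the series, first, only, none or still open, it means among the compounds named here.

Compound 2 `N=C(NCCCc1c[nH]cn1)NC(=O)CC(c1ccccc1)c1ccccn1` gives 97% in a functional assay on cardiac atrium for agonist activity at histamine H2 receptor (Cavia porcellus); a lower number here means a smaller maximal response, a higher number a larger maximal response; compound 1 `N=C(NCCCc1c[nH]cn1)NC(=O)CC(c1ccccc1)c1ccc(F)cc1` gives 95%, and the two numbers stand within the scatter of each other, the step being a number 2 percentage points higher from compound 1 to compound 2 (within the scatter). Compound 3 `N=C(NCCCc1c[nH]cn1)NC(=O)CC(c1ccccc1)c1nccs1` differs from compound 2 in one place: 1,3-thiazol-2-yl in place of pyridin-2-yl on a saturated chain carbon bound to an aromatic carbon and a saturated chain carbon. For the measured compounds named here, the only measured step, an exchange of one aryl group for another at the same place, left the maximal response essentially unchanged, so no step beyond the scatter is expected in this assay. Compound 3 is therefore expected to reach 95%, between 85% and 103%. The expected step of a number 2 percentage points lower from compound 2 to compound 3 (within the scatter) stays within the scatter.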

Compound 3, largest response reached (Emax), in percent of the reference or control that the assay uses: 100%
Compound 3: middle estimate off by 5 percentage points, on the low side; low and high end bracket the measured number.
By their numbers in this assay, from the lowest: compounds 1, 2 and 3 (each within the scatter of the next).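

Replacing the six-membered aromatic ring with a five-membered, sulfur-bearing one on the saturated chain carbon keeps the maximal response within the scatter in this assay, with a number 3 percentage points higher from compound 2 to compound 3 (within the scatter) and a number 5 percentage points higher from compound 1 to compound 3 (within the scatter). Across these three compounds, the change in ring size and hetero atoms produces no step beyond the scatter. Nothing shown here offers an explanation for this result. The compounds shown leave open whether the response would hold with a non-aromatic group at this place, such as a cyclohexyl group, an amine or a carboxylic acid.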